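The source may hold more compounds than are shown below. What is called first, only, known or untested is meant among the compounds shown, and "the series" means these compounds.

In a functional assay on SEM cells (Homo sapiens) for inhibition, read by MTT assay, with a stated time of 72 h (on this read-out lower numbers stand for stronger inhibition and higher numbers for weaker inhibition), compound 1 (`C=C(Br)C(=O)Nc1cccc(/C=C/C(=O)Nc2ccccc2)c1`) gives 1100 nM and compound 2 (`C=C(Br)C(=O)Nc1cccc(/C=C/C(=O)Nc2ccc(Cl)cc2)c1`) gives 1190 nM, while compound 3 (`C=C(Br)C(=O)Nc1cccc(/C=C/C(=O)Nc2ccc(OC)cc2)c1`) gives 70 nM as the lowest of the three numbers. Compound 4 (`C=C(Br)C(=O)Nc1cccc(/C=C/C(=O)Nc2ccc(OC(F)(F)F)cc2)c1`) is not yet measured and differs from compound 3 as follows (trifluoromethyl in place of methyl on an oxygen on an aromatic ring): trifluoromethyl in place of methyl on an oxygen on an aromatic ring. The step of a 1.1-fold higher number from compound 1 to compound 2 (0.03 log units; within the scatter) stays within the scatter, whereas a 16-fold lower number from compound 1 to compound 3 (1.20 log units; beyond the scatter) and a 17-fold lower number from compound 2 to compound 3 (1.23 log units; beyond the scatter) are both large. Among the compounds with values here, no measured compound carries trifluoromethoxy, so the size of the step is uncertain. With compound 3 alone at 70 nM a partial return toward the other two numbers is expected, a rise beyond the scatter in this assay and smaller than those large steps. The expected step is a 5.7-fold higher number from compound 3 to compound 4 (0.76 log units; beyond the scatter) on this estimate. For compound 4 the estimated value is 400 nM with an expected range from 100 nM to 1400 nM in this series.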

Compound 4, half-maximal inhibitory concentration: 19300 nM
Compound 4: middle estimate off by 48-fold (1.68 log units), on the low side, and the stated range ends below it.
By their numbers in this assay, from the lowest: compound 3; then compounds 1 and 2 (each within the scatter of the next); then compound 4.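

In this assay, keeping the oxygen and exchanging only methyl for trifluoromethyl gives a 280-fold higher number from compound 3 to compound 4 (2.44 log units; beyond the scatter) and so reverses the gain seen with methoxy. Trifluoromethoxy also stands apart from the chloro and hydrogen compounds, with a 16-fold higher number from compound 2 to compound 4 (1.21 log units; beyond the scatter) and an 18-fold higher number from compound 1 to compound 4 (1.24 log units; beyond the scatter) showing that this place can weaken inhibition as well as strengthen it. No evidence given here accounts for these steps.

Open, as far as these compounds go, is whether difluoromethoxy would stand nearer compound 3 or compound 4. Also open, from the compounds shown here alone, is whether ethoxy, a longer alkoxy chain or a dimethylamino group would keep the low number of compound 3.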